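The source may hold more compounds than are shown below. What is called first, only, known or untested is meant among the compounds shown, and "the series" means these compounds.

Working notes on the series.

Of the compounds shown here, three have been measured so far in a functional assay on HeLa cells (Homo sapiens) for antiproliferative activity, with a stated time of 5 days; on this read-out higher numbers stand for weaker inhibition and lower numbers for stronger inhibition. Compound 1 `O=C1C=CC2(C=C1)OCC(=O)N2c1nc(-c2ccc3ccccc3c2Br)nn1-c1ccccc1` gives 290 nM in this assay, the lowest of the three numbers. Compound 3 `CC1OC2(C=CC(=O)C=C2)N(c2nc(-c3ccc4ccccc4c3)nn2-c2ccc3ccccc3c2)C1=O` gives 300 nM, which sits within the scatter of the value for compound 1, so no order can be drawn between the two. Compound 2 `O=C1C=CC2(C=C1)OCC(=O)N2c1nc(-c2ccc3ccccc3c2)nn1-c1ccc(Cl)cc1` gives 720 nM, a higher number than that of compound 1 by a gap beyond the scatter. No pair among these three differs in one place only, so no single step has been isolated yet.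

Compound 4 `O=C1C=CC2(C=C1)OCC(=O)N2c1nc(-c2ccc3ncccc3c2)nn1-c1ccccc1` is the next to be measured in this assay. It is compound 1 with quinolin-6-yl in place of 1-bromonaphthalen-2-yl on an aromatic carbon. The change leaves out the bromine and brings in one ring nitrogen as a hydrogen-bond acceptor, with one heavy atom fewer. Within the data shown here, no measured pair shows this change, so its size is not known from the data. The expectation for the step from compound 1 to compound 4 is a 1.7-fold higher number from compound 1 to compound 4 (0.24 log units; within the scatter), a modest move toward a higher number that may still fall within the scatter. Compound 4 is accordingly estimated at 500 nM in this assay, with a range from 150 nM to 1800 nM.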

Compound 4, half-maximal inhibitory concentration: 110 nM
Estimate against measurement, compound 4: 4.5-fold (0.66 log units) above; the whole stated range lies above it.
By their numbers in this assay, from the lowest: compound 4; then compounds 1 and 3 (each within the scatter of the next); then compound 2.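

In this assay, the aromatic carbon between two ring nitrogen atoms now has its first isolated single step: quinolin-6-yl in place of 1-bromonaphthalen-2-yl gives a 2.6-fold lower number from compound 1 to compound 4 (0.42 log units; beyond the scatter). The bromine is therefore not required at this position for a low number, since compound 4 lacks it and still has the lower number of the pair, and a group with a ring nitrogen as hydrogen-bond acceptor is accepted here without loss. No supporting data bear on the reason for this step.

The step combines two changes, the loss of the bromine and the entry of the ring nitrogen, so the compounds shown cannot assign the gain to either one, and one pair gives no trend for this position. Also open, from the compounds shown here alone, is how the number would respond to other groups at this place, such as a pyridin-3-yl ring or a quinolin-6-yl group carrying an amine or a carboxylic acid, and whether the step would hold with a substituent other than the phenyl group on the ring nitrogen.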